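The source may hold more compounds than are shown below. What is called first, only, known or untested is meant among the compounds shown, and "the series" means these compounds.

Going by the values given here, compound 3 `Fc1ccc(-c2nn3ccc(NC4CCCC4)cc3c2-c2ccnc(NC3CCCC3)n2)cc1` holds the only number so far in an ADME assay on Vero cells (Chlorocebus sabaeus) for cytotoxicity; a lower number here means that less compound is tolerated, a higher number that more compound is tolerated: compound 3 gives 18000 nM. Compound 1 `Fc1ccc(-c2nn3c(NC4CCCC4)cccc3c2-c2ccnc(NC3CCCC3)n2)cc1` sits at a limit of the assay, > 160000 nM. Compound 2 `Fc1ccc(-c2nn3ccc(Cl)cc3c2-c2ccnc(NC3CCCC3)n2)cc1` likewise sits at a limit of the assay, > 40000 nM. Among the compounds with values here, the single measured step, an at least 2.2-fold lower number from compound 2 to compound 3 (0.34 log units; beyond the scatter), is the only guide. Compound 4 `Nc1ccn2nc(-c3ccc(F)cc3)c(-c3ccnc(NC4CCCC4)n3)c2c1` differs from compound 3 by hydrogen in place of cyclopentyl on a nitrogen on an aromatic ring. Putting a cyclopentylamino in place of chloro lowered the number from compound 2 to compound 3, and compound 4 removes that cyclopentyl again, so the number is expected to move back up toward the limit recorded for compound 2 (the limit of > 40000 nM in this assay, at which 1 of the 3 values shown sits). The expected step is a 2.2-fold higher number from compound 3 to compound 4 (0.35 log units; beyond the scatter). Compound 4 is estimated at 40000 nM, with a range from 15000 nM to 160000 nM.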

Compound 4, half-maximal cytotoxic concentration: 20000 nM
Compound 4: the middle estimate sits 2.0-fold (0.30 log units) above what was measured, and the stated range covers the measured number.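

In this assay, the cyclopentyl on this nitrogen carries no readable weight: compound 4, with hydrogen in its place, stays level with compound 3 (a 1.1-fold higher number from compound 3 to compound 4 (0.05 log units; within the scatter)). The lower number seen with cyclopentylamino is therefore not tied to the cyclopentyl. The comparison of amino with chloro gives only a floor (an at least 2.0-fold lower number from compound 2 to compound 4 (0.30 log units; that floor lies within the scatter)), because compound 2 stands at a limit: (the limit of > 40000 nM in this assay, at which 1 of the 4 values shown sits). Open, going by these compounds, is whether a methyl, an acetyl or a longer chain on this nitrogen stays level with compound 3 and compound 4. On these data alone, a measured number for the chloro compound also remains open.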